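Methyl in Place of Dimethylamino on an Inactive Scaffold

This account rests on a few compounds, and the source may have more. Where it says the series, first, only, none or still open, it means among the compounds named here.

Compound 3 `Cc1c(-c2csc(/N=C3\S/C(=C\c4ccc(N(C)C)cc4)C(=O)N3c3ccccc3)n2)c(=O)n(-c2ccccc2)n1C` belongs to a small set that also contains compound 1 `CC(=O)c1nn(-c2ccccc2)/c(=N/c2nc(-c3c(C)n(C)n(-c4ccccc4)c3=O)cs2)s1` and compound 2 `Cc1c(-c2csc(/N=C3\S/C(=C\c4ccc(Cl)cc4)C(=O)N3c3ccccc3)n2)c(=O)n(-c2ccccc2)n1C`. In a functional assay on A549 cells (Homo sapiens) for cytotoxicity, read by sulforhodamine B assay, with a stated time of 72 h (on this read-out higher numbers stand for weaker inhibition and lower numbers for stronger inhibition), compound 3 gives > 100000 nM, which is a limit of the assay and not a number. Compound 2 likewise reaches only a limit, > 100000 nM. Compound 1 also stops at a limit, > 100000 nM. Among the measured compounds shown here, the one measured step, a step that the two limits leave unreadable from compound 2 to compound 3, therefore has no readable size, since both ends sit at the edge of what the assay can report; the limit of > 100000 nM in this assay, at which 3 of the 3 values shown sit, summarises where all three values stand.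

Compound 4 `Cc1ccc(/C=C2\S/C(=N\c3nc(-c4c(C)n(C)n(-c5ccccc5)c4=O)cs3)N(c3ccccc3)C2=O)cc1` differs from compound 3 by methyl in place of dimethylamino on an aromatic carbon. No measured step separates an active from an inactive compound here, so the change offers no reason to expect a measurable number. Because the limit of > 100000 nM in this assay, at which 3 of the 3 values shown sit, holds every value shown, compound 4 is expected to remain at that limit as well. Compound 4 is thus estimated at 100000 nM in this assay, within a range from 50000 nM to 300000 nM. The expected step of a number no higher from compound 3 to compound 4 (the limit leaves the size open) is none beyond the scatter.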

Compound 4, half-maximal inhibitory concentration: > 100000 nM
Compound 4: a limit, no number (the forecaster's own chance of this, stated with the estimate: 85%); the middle value lies on the limit itself.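

Compound 4 also stops at a limit, so the steps to it from compound 2 and from compound 3 cannot be read: the limit of > 100000 nM in this assay, at which 4 of the 4 values shown sit.

The compounds shown leave open whether any group on this shared core gives a measurable number in this assay.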